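Notes on a thiazole-pyrimidinone series: chloro to methoxy swap

This account rests on a few compounds, and the source may have more. Where it says the series, first, only, none or still open, it means among the compounds named here.

Measured so far in a functional assay on U-87MG ATCC cells for antiproliferative activity against U-87 MG (Homo sapiens), read by MTT assay, with a stated time of 48 h, tested at 100 uM; a lower number here means a stronger effect, a higher number a weaker effect of the compound at the concentration tested:
- compound 1, `COc1ccc(-c2nc(SCC(=O)c3sc(-c4ccccc4)nc3C)[nH]c(=O)c2C#N)cc1`, gives 1.08%
- compound 2, `COc1ccc(-c2nc(C)c(C(=O)CSc3nc(-c4ccc(Cl)cc4)c(C#N)c(=O)[nH]3)s2)cc1`, gives 2.85%

Compound 2 holds the higher of the two numbers, but the gap to compound 1 lies within the scatter, so the two stand together and neither can be called weaker. Both numbers sit near the floor of the read-out.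

Compound 3, `COc1ccc(-c2nc(C)c(C(=O)CSc3nc(-c4ccc(OC)cc4)c(C#N)c(=O)[nH]3)s2)cc1`, is not yet measured. It differs from compound 2 by methoxy in place of chloro on an aromatic carbon. For the measured compounds named here, with no measured step to lean on, the expectation is a step of a number 0.2 percentage points higher from compound 2 to compound 3 (within the scatter) no larger than the scatter, in either direction, the result staying close to the floor. Compound 3 is estimated at 3%, within 0% to 12%.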

Compound 3, a percentage reported as activity, at one concentration (the size of the read-out at that concentration, not a potency): 11.5%
Compound 3: middle estimate off by 8.5 percentage points, on the low side; low and high end bracket the measured number.
By their numbers in this assay, from the lowest: compounds 1, 2 and 3 (each within the scatter of the next, the first and the last beyond it).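

In this assay, the swap of 4-chlorophenyl to 4-methoxyphenyl gives a number 8.7 percentage points higher from compound 2 to compound 3 (within the scatter), so this change alone does not separate the two compounds. Methoxy in place of hydrogen on a different aromatic ring gives a number 10.4 percentage points higher from compound 1 to compound 3 (beyond the scatter), the only modest step so far, and so the first change in the series to show beyond the scatter. No evidence at hand bears on the origin of this step.

Still open, as far as these compounds go, is how an amine or a carboxylic acid would read in place of chloro on this aromatic carbon. Also open, from the compounds shown here alone, is how a longer alkoxy chain would read in place of methoxy.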